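A few compounds are considered here, and "the series" means these few. Any claim that something is new, unique, unknown or untested is made for them only; others in the source may bear on it.

Measured in an assay on isolated protein for displacement of a labelled ligand from Apoptosis regulator Bcl-2 (Homo sapiens), read by fluorescence polarization; a lower number here means a stronger inhibitor, a higher number a weaker inhibitor:
compound 1 `CN(C)CC[C@H](CSc1ccccc1)Nc1ccc(S(=O)(=O)NC(=O)c2ccc(N3CCN(Cc4ccccc4-c4ccc(Cl)cc4)CC3)cc2)cc1` gives < 1 nM
compound 2 `CN(C)CC[C@H](CSc1ccccc1)Nc1ccc(S(=O)(=O)NC(=O)c2ccc(N3CCN(Cc4ccccc4-c4ccc(Cl)cc4)CC3)cc2)cc1S(=O)(=O)C(F)(F)F` gives < 1 nM
compound 3 `CN(C)CC[C@H](CSc1ccccc1)Nc1ccc(S(=O)(=O)NC(=O)c2ccc(N3CCN(Cc4ccccc4-c4ccc(Cl)cc4)CC3)cc2)cc1OC(F)(F)F` gives < 1 nM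

Each of these three values is a limit of this assay, not a number. Compound 3 therefore stands only at a limit in this assay, and the two further values shown are limits as well, so no ordering among the three compounds can be read. The steps between them reflect this: a step that the two limits leave unreadable from compound 1 to compound 2, a step that the two limits leave unreadable from compound 1 to compound 3 and a step that the two limits leave unreadable from compound 2 to compound 3 are all left unreadable by the two limits involved. The one firm point in this assay is the limit of < 1 nM in this assay, at which 3 of the 3 values shown sit, where all measured members of the series sit.

The next compound, compound 4 `CN(C)CC[C@H](CSc1ccccc1)Nc1ccc(S(=O)(=O)NC(=O)c2ccc(N3CCN(Cc4ccccc4-c4ccc(Cl)cc4)CC3)cc2)cc1C(=O)C(F)(F)F`, is to be measured in this assay. It differs from compound 3 by (trifluoromethyl)carbonyl in place of trifluoromethoxy on an aromatic carbon. Within the data shown here, no measured step speaks to this exchange in size or direction, since every step that varies the group at this aromatic carbon is unreadable. The step from compound 3 to compound 4 is expected to be small, a step that the limit leaves unreadable from compound 3 to compound 4, with the compound most likely remaining at the limit of this assay. Compound 4 is accordingly estimated at 0.7 nM, within a range from 0.2 nM to 3 nM.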

Compound 4, inhibition constant: < 1 nM
Compound 4 ended at the assay's limit; the forecaster's own chance of this, stated with the estimate: 70%; the middle value is on the limit's open side.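

In this assay compound 4 gives < 1 nM as a limit and not a number. Among these compounds, no step among compound 1, compound 2, compound 3 and compound 4 can be read, because all four share one limit: the limit of < 1 nM in this assay, at which 4 of the 4 values shown sit.

How the hydrogen, (trifluoromethyl)sulfonyl, trifluoromethoxy and (trifluoromethyl)carbonyl compounds rank in this assay remains open in the compounds shown.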